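Swapping the five-membered ring on the shared core

The source may hold more compounds than are shown below. What is called first, only, known or untested is meant among the compounds shown, and "the series" means these compounds.

Measured so far:
- compound 1, `CCOC(=O)C1=C(C)N/C(=N\C#N)NC1c1ccco1`: 900 nM
- compound 2, `CC1=C(C(=O)OC(C)C)[C@@H](c2ccco2)N/C(=N/C#N)N1`: 15.1 nM
- compound 3, `CC1=C(C(=O)OC(C)C)C(c2cccs2)N/C(=N/C#N)N1`: 349 nM

These three compounds were tested in an assay on HEK293 cells for displacement of a labelled ligand from adenosine receptor A2b (Homo sapiens), with a stated time of 30 min; a higher number here means a weaker inhibitor, a lower number a stronger inhibitor. Compound 3, with its thiophen-2-yl group, gives 349 nM. That places it second highest of the three numbers: compound 1 gives a higher number, and compound 2 gives a far lower one; both gaps lie beyond the usual scatter of the measurement.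

Compound 4, `CC1=C(C(=O)OC(C)C)C(c2ccoc2)N/C(=N/C#N)N1`, has not been measured. It differs from compound 3 in one place: furan-3-yl in place of thiophen-2-yl on a saturated ring carbon. Both groups are single five-membered aromatic rings with one hetero atom and one hydrogen-bond acceptor, so the change is small in size, but it alters both the hetero atom and the point at which the ring is attached to the saturated ring carbon.

Among the compounds with values here, no measured pair shows this exact change. Compound 2, which carries a furan ring attached at a different position, gives the lowest number, but that ring is not furan-3-yl, so it cannot be read directly across. A modest step is expected, with direction uncertain; the step of a 1.4-fold higher number from compound 3 to compound 4 (0.16 log units; within the scatter) is estimated to be within or just beyond the scatter. Compound 4 is expected to give about 500 nM, with a likely range from 100 nM to 2500 nM.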

Compound 4, inhibition constant: 59.4 nM
Compound 4: middle estimate off by 8.4-fold (0.93 log units), on the high side; the measured number lies below the stated range.
By their numbers in this assay, from the lowest: compound 2; then compound 4; then compound 3; then compound 1.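

In this assay the exchange of thiophen-2-yl for furan-3-yl on the saturated ring carbon gives a 5.9-fold lower number from compound 3 to compound 4 (0.77 log units; beyond the scatter) and so shows that this position responds clearly to a swap between two rings of the same size. The two groups have the same counts of hetero atoms and hydrogen-bond acceptors, so those counts alone do not foretell the result at this position. No measurement shown here explains the step.

The exchange changes the hetero atom and the point of attachment together, so these compounds cannot say which of the two accounts for the step. A thiophen-3-yl group on the same carbon would separate the two changes, while a phenyl ring there would show how this position responds to a six-membered aromatic ring.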